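The source may report more compounds than this note shows. Statements on the series, on what has been measured and on what is new or still open speak of the compounds shown alone.

In a functional assay on Ishikawa cells (Homo sapiens) for antiproliferative activity, read by CCK-8 assay, with a stated time of 48 h (on this read-out lower numbers stand for stronger inhibition and higher numbers for weaker inhibition), the measured compounds are:

Compound 1 `O=C(/C=C/CNCCOc1ccc(Oc2c(-c3ccc(F)cc3)sc3cc(O)ccc23)cc1)N1CCCC1`: 11300 nM
Compound 2 `CNC(=O)/C=C/CN1CC(Oc2ccc(Oc3c(-c4ccc(F)cc4)sc4cc(O)ccc34)cc2)C1`: > 25000 nM (a limit of the assay, not a number)
Compound 3 `C/C=C/C(=O)N1CC(Oc2ccc(Oc3c(-c4ccc(F)cc4)sc4cc(O)ccc34)cc2)C1`: 9400 nM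

Only two of these results are numbers. Compound 1 gives 11300 nM and compound 3 gives 9400 nM, and these two values lie within the scatter of each other.

Compound 4 `O=C(CCCNCCOc1ccc(Oc2c(-c3ccc(F)cc3)sc3cc(O)ccc23)cc1)N1CCC1` carries 2-((3-((azetidin-1-yl)carbonyl)propyl)amino)ethyl in place of 1-((prop-1-en-1-yl)carbonyl)azetidin-3-yl on an oxygen on an aromatic ring.

For the measured compounds named here, one measured step bears on this change, and only loosely: an at least 2.6-fold lower number from compound 2 to compound 3 (0.42 log units; beyond the scatter). It is modest and concerns a smaller change on an amine nitrogen in a ring, so it shows that the side chain can matter but does not fix a direction for this replacement. A small move towards weaker inhibition seems the likeliest outcome, and a result reported only as a limit remains possible. The expected step is a 1.5-fold higher number from compound 3 to compound 4 (0.17 log units; within the scatter), which would stay within the scatter. For compound 4 the estimated value is 14000 nM, with an expected range from 7000 nM to 28000 nM.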

Compound 4, half-maximal inhibitory concentration: > 25000 nM
Compound 4 ended at the assay's limit; the forecaster's own chance of this, stated with the estimate: 25%; middle value at least 1.7-fold (0.25 log units) from the limit.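

In this assay compound 4 gives > 25000 nM, which is a limit of the assay and not a number. Even so, 2-((3-((azetidin-1-yl)carbonyl)propyl)amino)ethyl in place of 1-((prop-1-en-1-yl)carbonyl)azetidin-3-yl on an oxygen on an aromatic ring gives an at least 2.6-fold higher number from compound 3 to compound 4 (0.42 log units; beyond the scatter), so replacing the whole group at this position can move the result beyond the scatter, which the earlier change on an amine nitrogen in a ring did not show. The chain itself also counts, as 2-((azetidin-1-yl)carbonyl)ethyl in place of 2-((pyrrolidin-1-yl)carbonyl)ethenyl on a saturated chain carbon bound to an amine nitrogen gives an at least 2.2-fold higher number from compound 1 to compound 4 (0.34 log units; beyond the scatter).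

Going by these compounds, the step between compound 2 and compound 4 cannot be read, as both values are limits: the limit of > 25000 nM in this assay, at which 2 of the 4 values shown sit. It remains open how a longer chain, or a carboxylic acid in place of the (azetidin-1-yl)carbonyl group, would read in this assay.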